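Adding a third fluoro to a series stuck at its limit

This account rests on a few compounds, and the source may have more. Where it says the series, first, only, none or still open, it means among the compounds named here.

- Compound 1 `C=C[C@@](C)(/C=C/c1ccc(Nc2ccc(F)cc2)cc1)CCC=C(C)C`: > 26000 nM
- Compound 2 `C=C[C@@](C)(/C=C/c1ccc(Nc2ccc(F)c(F)c2)cc1)CCC=C(C)C`: > 26000 nM
- Compound 3 `C=C[C@@](C)(/C=C/c1ccc(Nc2cc(F)cc(F)c2)cc1)CCC=C(C)C`: > 26000 nM

Compound 3 has only a limit in a functional assay on Raji cells (Homo sapiens) for cytotoxicity, with a stated time of 72 h (a lower number here means that less compound is needed, a higher number that more compound is needed for the effect), not a number, and it gives > 26000 nM. For the measured compounds named here, the other two entries are limits as well, so the series so far stands at the limit of > 26000 nM in this assay, at which 3 of the 3 values shown sit.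

Compound 4 `C=C[C@@](C)(/C=C/c1ccc(Nc2cc(F)c(F)c(F)c2)cc1)CCC=C(C)C` differs from compound 3 by one change: fluoro in place of hydrogen on an aromatic carbon. This turns 3,5-difluorophenyl to 3,4,5-trifluorophenyl.

The closest measured precedent is the same kind of swap, a step that the two limits leave unreadable from compound 1 to compound 2. The two other measured changes rearrange the fluoro groups: a step that the two limits leave unreadable from compound 1 to compound 3 and a step that the two limits leave unreadable from compound 2 to compound 3. None of these steps has a readable size, so they give no sign of any gain or loss in this assay.

No step beyond the usual scatter is expected in either direction, and the estimated step is a step that the limit leaves unreadable from compound 3 to compound 4. Another limit is the likeliest report. The estimate for compound 4 is 30000 nM, with an expected range from 14000 nM to 60000 nM.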

Compound 4, half-maximal effective concentration: > 26000 nM
Compound 4: no number, only a limit (the forecaster's own chance of this, stated with the estimate: 85%); the middle value does not contradict the limit.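

Compound 4 gives only a limit in this assay, > 26000 nM. For the compounds shown here, compound 1, compound 2, compound 3 and compound 4 all give limits, and no step among them can be read. The compounds shown leave open whether adding or moving fluoro groups changes the effect at all.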